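Longer dialkylamino chains on a shared core

A few compounds are considered here, and "the series" means these few. Any claim that something is new, unique, unknown or untested is made for them only; others in the source may bear on it.

Measured compounds:
- compound 1 `CN(C)CCN(C)c1ncc2c(n1)CCN(C(=O)c1cc(Cc3n[nH]c(=O)c4ccccc34)ccc1F)C2` in a functional assay on MDA-MB-231 cells (Homo sapiens) for inhibition, read by MTT assay, with a stated time of 48 h; a lower number here means a stronger inhibitor, a higher number a weaker inhibitor: > 200000 nM, a limit of the assay
- compound 2 `CCN(CC)c1ncc2c(n1)CCN(C(=O)c1cc(Cc3n[nH]c(=O)c4ccccc34)ccc1F)C2` in this assay: > 200000 nM, a limit of the assay

Compound 2 gives only a limit in this assay, as the limit of > 200000 nM in this assay, at which 2 of the 2 values shown sit, records. The step that the two limits leave unreadable from compound 1 to compound 2 is therefore not readable. Compound 3 `CCCCN(CCCC)c1ncc2c(n1)CCN(C(=O)c1cc(Cc3n[nH]c(=O)c4ccccc34)ccc1F)C2` carries the change (dibutylamino in place of diethylamino on an aromatic carbon). Among the measured compounds shown here, no measured step bears on this change, and the two limits give no direction. The step of a number no higher from compound 2 to compound 3 (the limit leaves the size open) is expected to leave compound 3 at a limit again. For compound 3 the estimate is 200000 nM, within 50000 nM to 800000 nM.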

Compound 3, half-maximal inhibitory concentration: > 200000 nM
Compound 3: no number, only a limit; the forecaster's own chance of this, stated with the estimate: 85%; the middle value sits exactly at the limit.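

Compound 3 also gives only a limit in this assay, so no step among compound 1, compound 2 and compound 3 can be read: the limit of > 200000 nM in this assay, at which 3 of the 3 values shown sit.

The compounds shown leave open whether these amino groups differ at all in their effect in this assay.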